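The source may hold more compounds than are shown below. What is called first, only, known or untested is meant among the compounds shown, and "the series" means these compounds.

Working notes on the series. Compound 1 `O=C1CSC(c2ccccc2)N1n1c(CSc2nnc(-c3ccncc3)o2)nc2ccccc2c1=O` gives 30.1% in a functional assay on the whole organism (strain Charles-Foster albino) for inhibition, with Rattus norvegicus as the target, read by paw edema, at a dose of 50 mg/kg by the oral route; on this read-out higher numbers stand for more inhibition at the one dose given (going by the name of the read-out) and lower numbers for less inhibition. Compound 2 `O=c1c2ccccc2nc(CSc2nnc(-c3ccncc3)o2)n1/N=C/c1ccc(O)cc1` gives 18.2% in this assay; the step of a number 11.9 percentage points lower from compound 1 to compound 2 (beyond the scatter) concerns the group on the aromatic nitrogen of the core. Compound 3 `O=c1c2cc(Br)ccc2nc(CSc2nnc(-c3ccncc3)o2)n1/N=C/c1ccc(Cl)cc1` gives 26.4% in this assay; its number differs from that of compound 1 and from that of compound 2 only within the usual scatter, so no order among the three compounds can be read from these numbers.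

Compound 4 `O=c1c2ccccc2nc(CSc2nnc(-c3ccncc3)o2)n1/N=C/c1ccc(Cl)cc1` differs from compound 3 by hydrogen in place of bromo on an aromatic carbon. Going by the values given here, no measured step touches this place: the one step known, a number 11.9 percentage points lower from compound 1 to compound 2 (beyond the scatter), changes the group on the aromatic nitrogen, and compound 2 and compound 3 differ at two places at once, so their values do not isolate the bromo on its own. With nothing bearing directly on this change, the step of a number 0.4 percentage points lower from compound 3 to compound 4 (within the scatter) is expected to stay within the scatter. Compound 4 is therefore estimated at 26% in this assay, within 14% to 38%.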

Compound 4, a percentage reported as inhibition, in the whole organism at one dose (the size of the read-out at that dose, not a potency): 23.7%
Beside the measured number, compound 4's estimate is 2.3 percentage points above it, and the stated range covers the measured number.
By their numbers in this assay, from the lowest: compounds 2, 4, 3 and 1 (each within the scatter of the next, the first and the last beyond it).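

In this assay, going by these compounds alone, the first step at the bromo place, on an aromatic carbon of the fused system, is a number 2.7 percentage points lower from compound 3 to compound 4 (within the scatter), so with the chloro group held constant, bromo and hydrogen cannot be told apart here. Chloro in place of hydroxy gives a number 5.5 percentage points higher from compound 2 to compound 4 (within the scatter), and the exchange of groups on the aromatic nitrogen gives a number 6.4 percentage points lower from compound 1 to compound 4 (within the scatter), so compound 4 cannot be separated from any of the other three, even though compound 1 and compound 2 stand beyond the scatter of each other. Nothing at hand explains how closely these numbers lie.

Only bromo and hydrogen are shown at this place, so it remains open whether an amine or a methoxy group there would give a step beyond the scatter. Also open, on these data alone, is whether a carboxylic acid in place of chloro or hydroxy would do so.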